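The source may report more compounds than this note shows. Statements on the series, on what has been measured and on what is new or still open speak of the compounds shown alone.

In a functional assay on SK-OV-3 cells (Homo sapiens) for antiproliferative activity, read by MTT assay, with a stated time of 48 h (a higher number here means a weaker inhibitor, a lower number a stronger inhibitor), compound 1 `CCOc1ccc(-c2nc(N(Cc3ccccc3)Cc3ccccc3)sc2-c2cc(OC)c(OC)c(OC)c2)cc1` gives > 5000 nM as a limit, not a number. Compound 2 `CCOc1ccc(-c2nc(NS(=O)(=O)c3ccc([N+](=O)[O-])cc3OC)sc2-c2cc(OC)c(OC)c(OC)c2)cc1` gives > 5000 nM as a limit too. Compound 2 therefore sits at the limit of > 5000 nM in this assay, at which 2 of the 2 values shown sit, and has no exact number of its own. Compound 3 `CCOc1ccc(-c2nc(NS(=O)(=O)c3ccc(C)c(C)c3)sc2-c2cc(OC)c(OC)c(OC)c2)cc1` carries 3,4-dimethylphenyl in place of 2-methoxy-4-nitrophenyl on a sulfonyl sulfur. Among the compounds with values here, no measured step exists to go by, so no shift beyond the usual scatter is expected, and the estimated change is a number no higher from compound 2 to compound 3 (the limit leaves the size open) for now. The estimate for compound 3 is 5000 nM with 1200 nM to 20000 nM as the expected range.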

Compound 3, half-maximal inhibitory concentration: > 5000 nM
Compound 3: no number, only a limit; the forecaster's own chance of this, stated with the estimate: 60%; the middle value sits exactly at the limit.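

In this assay compound 3 gives > 5000 nM, a limit and not a number. Compound 2 also stands at a limit, so the step between compound 2 and compound 3 cannot be read. The compounds shown leave open whether any group on the sulfonyl sulfur would give an exact value in this assay.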